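From phenyl to (tert-butoxy)methyl: compound 1 and compound 4

The source may hold more compounds than are shown below. What is called first, only, known or untested is meant among the compounds shown, and "the series" means these compounds.

Values in an ADME assay on liver for metabolic stability, with Liver microsome (Homo sapiens) as the target, read by LC-MS, using microsomes; a lower number here means slower removal, a higher number faster removal of the compound:
- compound 1 `O=C(NCc1cc(Cl)ccc1-n1cnnn1)[C@@H]1[C@H]2C[C@H]2CN1C(=O)[C@H](O)c1ccccc1`: 61 mL.min-1.g-1
- compound 2 `CC(C)(C)[C@@H](O)C(=O)N1[C@@H]2C[C@@H]2C[C@H]1C(=O)NCc1cc(Cl)ccc1-n1cnnn1`: 54 mL.min-1.g-1
- compound 3 `O=C(NCc1cc(Cl)ccc1-n1cnnn1)[C@@H]1[C@@H]2C[C@@H]2CN1C(=O)[C@H](O)c1ccccc1`: < 15 mL.min-1.g-1 (a limit)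

In this assay, compound 1 gives 61 mL.min-1.g-1. Compound 2 gives 54 mL.min-1.g-1, and the two values lie within the scatter of each other. Compound 3 is reported only as a limit, < 15 mL.min-1.g-1.

Compound 4 `CC(C)(C)OC[C@@H](O)C(=O)N1C[C@@H]2C[C@@H]2[C@H]1C(=O)NCc1cc(Cl)ccc1-n1cnnn1` carries (tert-butoxy)methyl in place of phenyl on a saturated chain carbon bound to a carbonyl carbon and an oxygen on a saturated carbon.

Going by the values given here, the only measured step is an at least 4.0-fold lower number from compound 1 to compound 3 (0.60 log units; beyond the scatter), and it comes with the fact that compounds 1 and 3 differ only in the configuration as drawn. Compound 4 keeps the configuration drawn for compound 1, so that step gives no direction here. Among the compounds with values here, no measured step touches the exchanged group. The expectation therefore starts from compound 1 at 61 mL.min-1.g-1, and no step beyond the scatter is expected in this assay. The expected change is a 1.3-fold lower number from compound 1 to compound 4 (0.10 log units; within the scatter). Compound 4 is expected at 48 mL.min-1.g-1, with an estimated range from 22 mL.min-1.g-1 to 95 mL.min-1.g-1.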

Compound 4, intrinsic clearance in microsomes: 37 mL.min-1.g-1
For compound 4 the middle estimate is 1.3-fold (0.11 log units) above the measured one; low and high end bracket the measured number.
By their numbers in this assay, from the lowest: compounds 4, 2 and 1 (each within the scatter of the next). At a limit, below all of these: compound 3.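

At this place, on a saturated chain carbon bound to a carbonyl carbon and an oxygen on a saturated carbon, the exchange of phenyl for (tert-butoxy)methyl gives in this assay a 1.6-fold lower number from compound 1 to compound 4 (0.22 log units; within the scatter), so this is the first exchange of a group at this place that is shown. An aromatic ring can thus give way to a chain with no ring and one hydrogen-bond acceptor without a step beyond the scatter. Nothing given here accounts for the size of this step.

The compounds shown leave open whether an amine or a carboxylic acid on this carbon would bring a step beyond the scatter. They also leave open whether (tert-butoxy)methyl on the core as drawn in compound 3 would follow the step seen between compound 1 and compound 3.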